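This account rests on a few compounds, and the source may have more. Where it says the series, first, only, none or still open, it means among the compounds named here.

Of the compounds shown here, two have been measured in an assay on isolated protein for binding affinity to Neuropeptide Y receptor type 1 (Homo sapiens); a lower number here means a stronger inhibitor, a higher number a weaker inhibitor. Compound 1 `Oc1cccc2c1nc(COc1ccc(Cl)cc1)n2CCCC1CCCNC1` gives 5300 nM in this assay. Compound 2 `Clc1ccc(OCc2nc3ccccc3n2CCCC2CCCCN2)cc1` gives 3230 nM in this assay, the lower of the two numbers; the gap to compound 1 lies within the scatter, so no order between the two can be read. Compound 3 `Clc1ccc(OCc2nc3ccccc3n2CCC2CCCCN2)cc1` is not yet measured. It differs from compound 2 by piperidin-2-yl in place of (piperidin-2-yl)methyl on a saturated chain carbon, two bonds along the chain from an aromatic nitrogen. Among the measured compounds shown here, no measured pair shows such a step, so the change from compound 2 to compound 3 is expected to stay within the scatter, a 1.1-fold higher number from compound 2 to compound 3 (0.03 log units; within the scatter). For compound 3 the estimate in this assay is 3500 nM, in the range 1000 nM to 12000 nM.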

Compound 3, inhibition constant: 7860 nM
Compound 3: middle estimate off by 2.2-fold (0.35 log units), on the low side; low and high end bracket the measured number.
By their numbers in this assay, from the lowest: compounds 2, 1 and 3 (each within the scatter of the next, the first and the last beyond it).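

In this assay the length of the chain carrying the piperidine ring now registers: 2-(piperidin-2-yl)ethyl in place of 3-(piperidin-2-yl)propyl gives a 2.4-fold higher number from compound 2 to compound 3 (0.39 log units; beyond the scatter) in this single pair. Among the compounds shown here, this is the first step beyond the scatter, and it is modest. Nothing at hand explains the step. Still open, going by these compounds, is whether a longer chain than 3-(piperidin-2-yl)propyl lowers or raises the number. Also open, on these data alone, is whether an open-chain amine, such as diethylamino, can replace the piperidine ring at this position.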